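This account rests on a few compounds, and the source may have more. Where it says the series, first, only, none or still open, it means among the compounds named here.

Working notes on the series in a functional assay on BGC-823 cells (Homo sapiens) for antiproliferative activity, read by MTT assay, tested at 5 uM; on this read-out lower numbers stand for a weaker effect and higher numbers for a stronger effect at the one concentration tested. Going by the values given here, compound 1 `COc1cc(C(=O)N/N=C/c2ccc(F)c(F)c2)cc(OC)c1OC` gives 51.9%, and compound 3 `COc1cc(C(=O)N/N=C/c2ccc(F)cc2)cc(OC)c1OC` gives 61.1%; the one measured step, a number 9.2 percentage points higher from compound 1 to compound 3 (within the scatter), stays within the scatter. Compound 2 `COc1ccc(OC)c(C2OC(c3cc(OC)c(OC)c(OC)c3)=NN2C(C)=O)c1` gives 18.2%, the lowest of the three numbers, beyond the scatter below both compound 1 and compound 3. Compound 4 `COc1cc(C2=NN(C(C)=O)C(c3ccc(Cl)c([N+](=O)[O-])c3)O2)cc(OC)c1OC` is not yet measured; it differs from compound 2 by 4-chloro-3-nitrophenyl in place of 2,5-dimethoxyphenyl on a saturated ring carbon. Among the compounds with values here, the only measured step concerns a fluoro on an aromatic carbon in the core shared by compound 1 and compound 3, not an exchange of the whole aryl group on the saturated ring carbon, so it does not bear on this change, and no direction beyond the scatter can be expected. Compound 4 is therefore expected near 22%, with a range from 5% to 48%. This corresponds to an expected step of a number 3.8 percentage points higher from compound 2 to compound 4 (within the scatter).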

Compound 4, a percentage reported as inhibition, at one concentration (the size of the read-out at that concentration, not a potency): 0%
For compound 4 the middle estimate is 22 percentage points above the measured one; measured number outside the range, below it.
By their numbers in this assay, from the lowest: compound 4; then compound 2; then compounds 1 and 3 (each within the scatter of the next).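

In this assay, going by these compounds alone, the step of a number 18.2 percentage points lower from compound 2 to compound 4 (beyond the scatter) is the first measured change of the aryl group on the saturated ring carbon, and it shows that this position does not tolerate every exchange. With 4-chloro-3-nitrophenyl in place of 2,5-dimethoxyphenyl, the modest effect of compound 2 is lost. Nothing measured here explains the step. 

Still open, on these data alone, is whether the chloro or the nitro group alone accounts for the loss, since the two enter together. Also open, as far as these compounds go, is whether an aminophenyl or hydroxyphenyl group on the same carbon would restore the effect.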